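A few compounds are considered here, and "the series" means these few. Any claim that something is new, unique, unknown or untested is made for them only; others in the source may bear on it.

Working notes on the series.

Compound 1 `CC1=CCC2C(CC[C@@]2(C)O)C(C)(C)C1CC[C@@H]1[C@@]2(C)CC[C@@H](O)C(C)(C)O[C@@H]2CC[C@]1(C)O` is the starting point; in a functional assay on MCF7 cells (Homo sapiens) for antiproliferative activity, read by MTT assay, with a stated time of 72 h (a higher number here means a weaker inhibitor, a lower number a stronger inhibitor), compound 1 gives 44500 nM. Compound 2 `CC1=CCC2C(CC[C@@]2(C)O)C(C)(C)C1CC[C@@H]1[C@@]2(C)CCC(=O)C(C)(C)O[C@@H]2CC[C@]1(C)O` carries a ketone where compound 1 has a hydroxyl. In this assay compound 2 gives only the limit > 50000 nM, not a number. Compound 3 `CC1=CC[C@H]2[C@H](CC[C@]2(C)O)C(C)(C)[C@@H]1CC[C@H]1[C@]2(C)CC[C@H](OC(=O)NS(=O)(=O)c3ccc(C)cc3)C(C)(C)O[C@H]2CC[C@@]1(C)O` is the sulfonylcarbamate of the same hydroxyl. In this assay compound 3 likewise gives only the limit > 50000 nM; the value is a limit of the assay and no number. Compound 3 therefore stands with compound 2 at the weak end of what is shown, and the only numeric value is that of compound 1; nothing beyond the scatter separates these three.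

Compound 4 `CC1=CC[C@H]2[C@H](CC[C@]2(C)O)C(C)(C)[C@@H]1CC[C@H]1[C@]2(C)CC[C@H](OC(=O)c3ccccc3F)C(C)(C)O[C@H]2CC[C@@]1(C)O` differs from compound 3 in one place (2-fluorophenyl in place of ((4-methylphenyl)sulfonyl)amino on a carbonyl carbon). Within the data shown here, no step between measured compounds is available, and since compound 3 sits at the limit of > 50000 nM in this assay, at which 2 of the 3 values shown sit, the step to compound 4 cannot be sized downward with certainty. Given that compound 1, compound 2 and compound 3 all lie at or near the same weak level, compound 4 is expected near that level as well, with an estimated step of an at least 1.2-fold lower number from compound 3 to compound 4 (0.09 log units; that floor lies within the scatter) that should not exceed the scatter. For compound 4 in this assay the estimate is 40000 nM, expected to fall between 15000 nM and 90000 nM.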

Compound 4, half-maximal inhibitory concentration: 11300 nM
Beside the measured number, compound 4's estimate is 3.5-fold (0.55 log units) above it; measured number below the stated range.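

In this assay, the group on this carbonyl carbon matters: replacing ((4-methylphenyl)sulfonyl)amino with 2-fluorophenyl gives an at least 4.4-fold lower number from compound 3 to compound 4 (0.64 log units; beyond the scatter). Among these compounds, of the compounds changed at this hydroxyl, compound 4 is the only one that returns a number, so the position tolerates at least one substituent that leaves measurable antiproliferative activity. The step is only a floor and its full size cannot be read, as the value for compound 3 is a limit of the assay and not a number: the limit of > 50000 nM in this assay, at which 2 of the 4 values shown sit.

The change removes the whole ((4-methylphenyl)sulfonyl)amino group and brings in an aryl group carrying fluorine, so it does not separate the loss of the sulfonylamino link from the presence of the fluorine, and an unsubstituted phenyl group on the same carbonyl carbon would be needed to tell these apart. Also open, going by these compounds, is how far the response extends beyond aryl groups on this carbonyl carbon, for instance to a longer alkyl chain, a simple amine or a group bearing a carboxylic acid, and whether any of these would move the value further from that of compound 4.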